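Aryl-to-isopropyl switch at the amidine nitrogen

This account rests on a few compounds, and the source may have more. Where it says the series, first, only, none or still open, it means among the compounds named here.

Measured so far in a functional assay on MCF7 cells (Homo sapiens) for cytotoxicity, read by MTT assay, with a stated time of 48 h; a lower number here means a stronger inhibitor, a higher number a weaker inhibitor:
- compound 1 `Cc1ccc(S(=O)(=O)/N=C(/CCNC2=CC(=O)c3ccccc3C2=O)Nc2ccccc2[N+](=O)[O-])cc1`: 3090 nM
- compound 2 `Cc1ccc(S(=O)(=O)/N=C(/CCNC2=CC(=O)c3ccccc3C2=O)Nc2cccc(C(F)(F)F)c2)cc1`: 89100 nM

Going by the values given here, compound 2 carries the highest number of the two measured in this assay; its nearest neighbour is compound 1, which sits at a markedly lower value, and the one measured step, a 29-fold higher number from compound 1 to compound 2 (1.46 log units; beyond the scatter), is well beyond the scatter. That step exchanges one aryl group for another on the amine nitrogen.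

Compound 3 `Cc1ccc(S(=O)(=O)/N=C(/CCNC2=CC(=O)c3ccccc3C2=O)NC(C)C)cc1` differs from compound 2 by isopropyl in place of 3-(trifluoromethyl)phenyl on an amine nitrogen. Among the compounds with values here, no measured step covers an aryl-to-alkyl exchange at this nitrogen; the only step available, a 29-fold higher number from compound 1 to compound 2 (1.46 log units; beyond the scatter), shows that this position is sensitive to what is attached, but it does not indicate how a small alkyl group behaves here. A large movement in either direction is therefore possible, and the expectation is correspondingly wide.

Compound 3 is estimated in this assay at 25000 nM, with a range from 3000 nM to 150000 nM; this means an expected step of a 3.6-fold lower number from compound 2 to compound 3 (0.55 log units; beyond the scatter), modest and uncertain in direction.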

Compound 3, half-maximal inhibitory concentration: 16500 nM
For compound 3 the middle estimate is 1.5-fold (0.18 log units) above the measured one; low and high end bracket the measured number.
By their numbers in this assay, from the lowest: compound 1; then compound 3; then compound 2.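

Replacing an aryl group with isopropyl on this amine nitrogen does not have a single direction in this assay: the outcome depends on which aryl group leaves, with a 5.4-fold lower number from compound 2 to compound 3 (0.73 log units; beyond the scatter) but a 5.3-fold higher number from compound 1 to compound 3 (0.73 log units; beyond the scatter). An aromatic ring at this position is therefore not required for a measurable value, since compound 3 has no ring here and still falls inside the span set by the two aryl compounds, while the 2-nitrophenyl group of compound 1 gives the lowest number of the three, with steps to both others beyond the scatter. Nothing available bears on why the number moves in these two directions.

Three compounds cannot separate the loss of the ring itself from the loss of the trifluoromethyl or nitro group, and a plain phenyl or a cyclohexyl group at this nitrogen would address that distinction directly. On these data alone, how the number responds to alkyl groups other than isopropyl also remains open, whether a smaller methyl group, a longer chain such as n-butyl, or a chain ending in an amine.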